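The source may hold more compounds than are shown below. What is called first, only, known or untested is meant among the compounds shown, and "the series" means these compounds.

Compound 1 `C[C@H]1O[C@@H](n2cc(F)c(NC(=O)Oc3ccc([N+](=O)[O-])cc3)nc2=O)[C@@H]2OC(=O)O[C@@H]21` is the reference point of the series. In a functional assay on MCF7 cells (Homo sapiens) for cytotoxicity, read by MTT assay, with a stated time of 3 days (a higher number here means a weaker inhibitor, a lower number a stronger inhibitor), compound 1 gives 6 ug/mL. Compound 2 `C[C@H]1O[C@@H](n2cc(F)c(NC(=O)Oc3ccc([N+](=O)[O-])cc3)nc2=O)[C@H](O)[C@@H]1O` differs from compound 1 only in the core: a group of 8 heavy atoms (5 carbon, 3 oxygen; one five-membered non-aromatic ring with 1 hetero atom) in place of a group of 10 heavy atoms (6 carbon, 4 oxygen; one five-membered non-aromatic ring with 1 hetero atom, one five-membered non-aromatic ring with 2 hetero atoms), on an aromatic nitrogen. This change carries a 30-fold higher number from compound 1 to compound 2 (1.48 log units; beyond the scatter), and in this assay compound 2 gives 180 ug/mL, the highest of the three measured numbers. Compound 3 `CCC(C)COC(=O)Nc1nc(=O)n([C@@H]2O[C@H](C)[C@H]3OC(=O)O[C@H]32)cc1F` keeps the core of compound 1 and alters the carbamate end: 2-methylbutyl in place of 4-nitrophenyl on an oxygen next to a carbonyl group, a change that carries a 12-fold higher number from compound 1 to compound 3 (1.07 log units; beyond the scatter); in this assay compound 3 gives 70 ug/mL. Compound 4 `CCC(C)COC(=O)Nc1nc(=O)n([C@@H]2O[C@H](C)[C@@H](O)[C@H]2O)cc1F` is not yet measured; it carries the same change on the core of compound 2, at the same place: 2-methylbutyl in place of 4-nitrophenyl on an oxygen next to a carbonyl group. For compound 4 the step is expected to be a 5.6-fold higher number from compound 2 to compound 4 (0.74 log units; beyond the scatter), which rests on the single earlier case of this change, a 12-fold higher number from compound 1 to compound 3 (1.07 log units; beyond the scatter). The estimate for compound 4 in this assay is 1000 ug/mL, expected to fall between 300 ug/mL and 3000 ug/mL. A number this high may be reported only as a limit of the assay.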

Compound 4, half-maximal inhibitory concentration: 120 ug/mL
Compound 4: middle estimate off by 8.3-fold (0.92 log units), on the high side; measured number outside the range, below it.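

On the core of compound 2, 2-methylbutyl in place of 4-nitrophenyl in this assay gives a 1.5-fold lower number from compound 2 to compound 4 (0.18 log units; within the scatter) and the large rise seen on the core of compound 1 does not recur. The step therefore does not carry over as a fixed amount between these two cores: the same change on two cores in this assay, a 12-fold higher number (1.07 log units; beyond the scatter) from compound 1 to compound 3 and a 1.5-fold lower number (0.18 log units; within the scatter) from compound 2 to compound 4, 18-fold (1.24 log units) apart, beyond the scatter of two such steps. This rests on a single pair of steps and does not show what in the core sets the difference, nor whether it holds for other groups.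

Going by these compounds, how a shorter chain, a plain phenyl or a chain bearing an amine on an oxygen next to a carbonyl group would behave on either core remains open. On these data alone, whether any further core follows compound 1 or compound 2 is also open.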